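A Predicted Step from Compound 2 to Compound 3

This account rests on a few compounds, and the source may have more. Where it says the series, first, only, none or still open, it means among the compounds named here.

For compound 1 the value < 20% is a limit of the assay and not a number.

Measured compounds:
Compound 1 `C/C(=N\OCC(=O)O)c1ccc(C(C)(C)C)cc1`: < 20%
Compound 2 `C/C(=N\OCC(=O)O)c1ccc(N)cc1`: 20%

In a functional assay on the whole organism for inhibition, with Rattus norvegicus as the target, read by paw edema, with stated times of 1 h and 3 h, at a dose of 50 mg/kg by the oral route (on this read-out higher numbers stand for more inhibition at the one dose given (going by the name of the read-out) and lower numbers for less inhibition), compound 2 gives 20%, the only number shown for this read-out. The other value shown, that of compound 1, is a limit (the limit of < 20% in this assay, at which 1 of the 2 values shown sits). Among the measured compounds shown here, the one measured step, a number no lower from compound 1 to compound 2 (the limit leaves the size open), goes with amino in place of tert-butyl on an aromatic carbon, but since it starts from a limit its size cannot be read.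

Compound 3 `C/C(=N\OCC(=O)O)c1ccc(N(C)C)cc1` has not yet been measured. It differs from compound 2 in one place: dimethylamino in place of amino on an aromatic carbon. No measured step touches this change, and the single step that exists leaves its own size open, so nothing shown points to a rise or a fall beyond the scatter. Compound 3 is therefore expected to sit close to compound 2 in this assay, with the expected step being no change at the digits printed from compound 2 to compound 3 (within the scatter). The estimate for compound 3 is 20%, expected to fall between 5% and 40%.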

Compound 3, a percentage reported as inhibition, in the whole organism at one dose (the size of the read-out at that dose, not a potency): < 20%
Compound 3: a limit, no number (the forecaster's own chance of this, stated with the estimate: 40%); the middle value lies on the limit itself.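

In this assay compound 3 gives < 20% as a limit of the assay and not a number. At this position, on an aromatic carbon, dimethylamino in place of amino gives a number no higher from compound 2 to compound 3 (the limit leaves the size open), so adding carbon to the nitrogen brings no sign of a gain in this read-out, although neither this step nor the step linking the tert-butyl and dimethylamino compounds can be read for size. Among the compounds shown here, compound 2 now stands as the only compound with a number, and most of the series sits at one limit: the limit of < 20% in this assay, at which 2 of the 3 values shown sit.

The compounds shown leave open whether another group at this position, such as a hydroxyl, a carboxylic acid or a longer chain on the nitrogen, would lift the read-out clear of that limit. They also leave open whether compound 1 and compound 3 differ from each other at all.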